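Fluoro to chloro on the core: expected step

This account rests on a few compounds, and the source may have more. Where it says the series, first, only, none or still open, it means among the compounds named here.

Compound 2 `Cc1ccccc1NC(=O)NC1CC(C)(C)Oc2ccc(F)cc21` is the measured anchor for this step. In a functional assay (aorta) with Rattus norvegicus as the target (a lower number here means that less compound is needed, a higher number that more compound is needed for the effect), compound 2 gives > 30000 nM, which is a limit of the assay and not a number. Compound 1 `COc1ccc(NC(=O)NC2CC(C)(C)Oc3ccc(Cl)cc32)cc1` carries the same urea and the same core, with a chloro group and a different aryl group on the urea. In this assay compound 1 gives > 30000 nM, again a limit. Going by the values given here, compound 2 therefore stands at the limit with the only other value shown, (the limit of > 30000 nM in this assay, at which 2 of the 2 values shown sit); compound 1 differs from compound 2 in more than one place, so its value only shows that it too sits at the limit, and no measured step of a single change is available.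

Compound 3 `Cc1ccccc1NC(=O)NC1CC(C)(C)Oc2ccc(Cl)cc21` differs from compound 2 by chloro in place of fluoro on an aromatic carbon. With no measured step of this kind in the series, the expected step is a step that the limit leaves unreadable from compound 2 to compound 3, none beyond the scatter, due to the limit of > 30000 nM in this assay, at which 2 of the 2 values shown sit, where both values shown sit at the limit. Compound 3 is expected to give 40000 nM in this assay, within 10000 nM to 200000 nM, most likely reported again only as a limit.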

Compound 3, half-maximal effective concentration: > 10000 nM
Compound 3: a limit, no number; the forecaster's own chance of this, stated with the estimate: 80%; the middle value is on the limit's open side.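

In this assay compound 3 gives > 10000 nM, a limit and not a number. Compound 1 and compound 2 also stand only at limits, so the steps from each of them to compound 3 cannot be read. The compounds shown leave open what concentration, if any, gives the half-maximal effect for this urea series.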